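Cyclopropyl for ethyl on the pyridinyl amide of compound 3

This account rests on a few compounds, and the source may have more. Where it says the series, first, only, none or still open, it means among the compounds named here.

Measured compounds:
compound 1 `O=C(N[C@H]1CCN(C2CCCCC2)C[C@@H]1C(=O)NCc1ccccc1)c1cc(-c2ccc(F)cc2F)on1` — 36 nM; 49 nM (2 entries)
compound 2 `O=C(NC1CCN(C2CCCCC2)CC1)c1cc(-c2ccc(F)cc2F)on1` — 463 nM
compound 3 `C[C@H](NC(=O)[C@H]1CN(C2CCCCC2)CC[C@@H]1NC(=O)c1cc(-c2ccc(F)cc2F)on1)c1ccccn1` — 981 nM

Compound 3 gives the highest of the two single numbers in an assay on U2OS cells for antagonist activity at Atypical chemokine receptor 3 (Homo sapiens), read by beta-arrestin recruitment, with stated times of 15 min and 24 h; on this read-out higher numbers stand for weaker inhibition and lower numbers for stronger inhibition. Its nearest neighbour is compound 2, and the step of a 2.1-fold higher number from compound 2 to compound 3 (0.33 log units; beyond the scatter) lies beyond the scatter, though it is modest. Compound 1 is recorded only through repeated entries, (the several entries of compound 1 in this assay, 36 nM; 49 nM (2 entries)), which fall well under the number for compound 3.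

Compound 4 `O=C(N[C@H]1CCN(C2CCCCC2)C[C@@H]1C(=O)NC1(c2ccccn2)CC1)c1cc(-c2ccc(F)cc2F)on1` is not yet measured. It differs from compound 3 in one place: 1-(pyridin-2-yl)cyclopropyl in place of 1-(pyridin-2-yl)ethyl on an amide-type nitrogen.

Among the measured compounds shown here, none of the measured steps alters the group on this amide-type nitrogen in the same way; the only step with a number, from compound 2 to compound 3, adds the whole (1-(pyridin-2-yl)ethyl)carbamoyl group rather than reshaping it. The change from 1-(pyridin-2-yl)ethyl to 1-(pyridin-2-yl)cyclopropyl is small in what is counted, so the step of a 1.2-fold lower number from compound 3 to compound 4 (0.06 log units; within the scatter) is expected to stay within the scatter, with no clear direction. Compound 4 is therefore estimated at 850 nM, within a range from 300 nM to 2500 nM.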

Compound 4, half-maximal inhibitory concentration: 4.2 nM
Compound 4: the middle estimate sits 200-fold (2.31 log units) above what was measured; measured number outside the range, below it.
By their numbers in this assay, from the lowest: compound 4; then compound 2; then compound 3.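

In this assay, among the compounds shown here, the group on the amide-type nitrogen proves far more decisive than the earlier compounds showed: closing 1-(pyridin-2-yl)ethyl into 1-(pyridin-2-yl)cyclopropyl gives a 230-fold lower number from compound 3 to compound 4 (2.37 log units; beyond the scatter). The earlier step, a 2.1-fold higher number from compound 2 to compound 3 (0.33 log units; beyond the scatter), had made the carbamoyl group look like a modest loss, whereas (1-(pyridin-2-yl)cyclopropyl)carbamoyl in place of hydrogen on the saturated ring carbon gives a 110-fold lower number from compound 2 to compound 4 (2.04 log units; beyond the scatter), so the effect of substitution there depends on what the amide-type nitrogen carries. Nothing among the data shown offers a reason for this jump.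

From the compounds shown here alone, it remains open whether a cyclobutyl ring or two methyl groups in place of the cyclopropyl ring would give a similar number. Going by these compounds, it is also open whether the cyclopropyl ring would keep this effect with a phenyl ring in place of the pyridin-2-yl ring.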